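The source may report more compounds than this note shows. Statements on the series, on what has been measured and on what is new or still open speak of the compounds shown alone.

Compound 1 `COc1ccc(C#Cc2ccc(C(=O)N3CC[C@@H](O)C3)cc2)cc1` gives 10200 nM in a functional assay on TREX cells for negative allosteric modulation of metabotropic glutamate receptor 3 (Rattus norvegicus), read by calcium flux, with a stated time of 2.5 min; a higher number here means a weaker inhibitor, a lower number a stronger inhibitor.
Compound 2 `COc1ccc(C#Cc2ccc(C(=O)N3CCC(CO)C3)cc2)cc1` gives 7590 nM in this assay.
Compound 3 `CCOc1ccc(C#Cc2ccc(C(=O)N3CCC[C@@H](CO)C3)cc2)cc1` gives only a limit of the assay in this assay, > 10000 nM.

Compound 2 and compound 1 lie within the scatter of one another, as the step of a 1.3-fold lower number from compound 1 to compound 2 (0.13 log units; within the scatter) shows; the third value is a limit, so compound 2 cannot be ranked against it. Compound 4 `COc1ccc(C#Cc2ccc(C(=O)N3CC4CCC(O)C4C3)cc2)cc1` differs from compound 2 in one place: a group of 9 heavy atoms (7 carbon, 1 nitrogen, 1 oxygen; one five-membered non-aromatic ring of carbon only, one five-membered non-aromatic ring with 1 hetero atom) in place of a group of 7 heavy atoms (5 carbon, 1 nitrogen, 1 oxygen; one five-membered non-aromatic ring with 1 hetero atom), on a carbonyl carbon. Among the measured compounds shown here, the only measured step, from compound 1 to compound 2, changed the group on the same carbonyl carbon and stayed within the scatter, so for compound 4 no step beyond the scatter is expected, a 1.1-fold higher number from compound 2 to compound 4 (0.02 log units; within the scatter). Compound 4 is therefore estimated at 8000 nM, with a range from 3000 nM to 25000 nM.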

Compound 4, half-maximal inhibitory concentration: 5500 nM
Beside the measured number, compound 4's estimate is 1.5-fold (0.16 log units) above it; the range from low to high includes it.
By their numbers in this assay, from the lowest: compounds 4, 2 and 1 (each within the scatter of the next).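

The group on the carbonyl carbon can grow to carry a five-membered ring of carbon only without a clear effect on the number: the change gives a 1.4-fold lower number from compound 2 to compound 4 (0.14 log units; within the scatter), and the comparison with the smaller group of compound 1 gives a 1.9-fold lower number from compound 1 to compound 4 (0.27 log units; within the scatter). So even this larger group does not separate from the smaller ones in this assay.

On these data alone, whether an amine or a carboxylic acid in place of the hydroxy group would move the number beyond the scatter stays open. The value of compound 3 is a limit of the assay and stays unranked: the limit of > 10000 nM in this assay, at which 1 of the 4 values shown sits.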